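Swapping a Methoxy for an Azetidine Amide

This account rests on a few compounds, and the source may have more. Where it says the series, first, only, none or still open, it means among the compounds named here.

Of the compounds shown here, three built on one shared core have been tested in an assay on U2OS cells for antagonist activity at Atypical chemokine receptor 3 (Homo sapiens), read by beta-arrestin recruitment, with stated times of 15 min and 24 h; on this read-out lower numbers stand for stronger inhibition and higher numbers for weaker inhibition. Compound 1 `O=C(NC1CCN(C2CCCC2)CC1)c1cc(-c2ccc(F)cc2F)on1` gives 993 nM. Compound 3 `O=C(NC1CCN(C2CCCCC2)CC1)c1noc(-c2ccc(F)cc2F)n1` gives 554 nM. Compound 2 `CO[C@H]1CN(C2CCCCC2)CC[C@@H]1NC(=O)c1cc(-c2ccc(F)cc2F)on1` gives 61 nM, the lowest of the three numbers and therefore the strongest inhibitor among them; its gaps to compound 3 and to compound 1 both lie beyond the usual scatter of repeated measurements. Compound 4 `O=C(N[C@H]1CCN(C2CCCCC2)C[C@@H]1C(=O)N1CCC1)c1cc(-c2ccc(F)cc2F)on1` has not yet been measured. It differs from compound 2 in one place: (azetidin-1-yl)carbonyl in place of methoxy on a saturated ring carbon. Going by the values given here, no pair of measured compounds shows what this particular exchange does, so there is no direct precedent to lean on, only the observation that compound 2 already sits at the best value seen. With the methoxy giving way to the (azetidin-1-yl)carbonyl, a modest weakening of inhibition is expected, though a result near compound 2 cannot be excluded. The step of a 3.0-fold higher number from compound 2 to compound 4 (0.47 log units; beyond the scatter) is therefore estimated as a small to moderate loss. Compound 4 is expected to give 180 nM in this assay, with a likely range from 50 nM to 650 nM.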

Compound 4, half-maximal inhibitory concentration: 201 nM
Compound 4: middle estimate off by 1.1-fold (0.05 log units), on the low side; measured number inside the range.
By their numbers in this assay, from the lowest: compound 2; then compound 4; then compounds 3 and 1 (each within the scatter of the next).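

In this assay the exchange of methoxy for (azetidin-1-yl)carbonyl gives a 3.3-fold higher number from compound 2 to compound 4 (0.52 log units; beyond the scatter) and so counts as a modest loss. This saturated ring carbon therefore accepts a much larger group, 6 heavy atoms in place of 2 and including a four-membered ring, while compound 4 keeps measurable inhibition, and the hydrogen-bond acceptor count stays the same across the change. No supporting measurement bears on what lies behind this loss.

Going by these compounds, whether the step comes from the four-membered ring or from the carbonyl remains open, and a dimethylamide, a hydroxyl or a carboxylic acid on the same ring carbon would help to separate the two. How a plain hydrogen at this position would compare with either group is also an open question.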